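Swapping methylsulfanyl for ethyl on a shared core

The source may hold more compounds than are shown below. What is called first, only, known or untested is meant among the compounds shown, and "the series" means these compounds.

Compound 1 `Cc1cc(Nc2ccc(C(F)(F)F)cc2)n2nc(C3CC3)nc2n1`: < 5 mL.min-1.g-1
Compound 2 `CSc1nc2nc(C)cc(Nc3ccc(C(F)(F)F)cc3)n2n1`: 18.7 mL.min-1.g-1

Going by the values given here, in an in vitro ADME assay on microsomes from liver (Homo sapiens) for metabolic stability (a higher number here means faster removal of the compound, a lower number slower removal), compound 2 gives 18.7 mL.min-1.g-1, the only true number so far. Compound 1 gives < 5 mL.min-1.g-1, which is a limit of the assay and not a number. Compound 3 `CCc1nc2nc(C)cc(Nc3ccc(C(F)(F)F)cc3)n2n1` has not yet been measured. It carries ethyl in place of methylsulfanyl on an aromatic carbon. Among the compounds with values here, only one measured step changes this same place, namely an at least 3.7-fold higher number from compound 1 to compound 2 (0.57 log units; beyond the scatter), with methylsulfanyl in place of cyclopropyl. Run in reverse, that step suggests a lower number when methylsulfanyl gives way to a carbon group, but ethyl is not cyclopropyl, and one step is a thin guide. A smaller fall in this assay is therefore expected. The expected change is a 2.1-fold lower number from compound 2 to compound 3 (0.32 log units; beyond the scatter). For compound 3 the estimate is 9 mL.min-1.g-1, with an expected range from 5 mL.min-1.g-1 to 18 mL.min-1.g-1.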

Compound 3, intrinsic clearance in microsomes: < 5 mL.min-1.g-1
Compound 3: only a limit was reported; the forecaster's own chance of this, stated with the estimate: 25%; middle value at least 1.8-fold (0.25 log units) away from the limit.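

In this assay, the change to ethyl gives an at least 3.7-fold lower number from compound 2 to compound 3 (0.57 log units; beyond the scatter), so replacing methylsulfanyl at this position matters even though the count of heavy atoms stays the same. Among the three compounds, methylsulfanyl now stands apart from two different carbon groups, ethyl and cyclopropyl, and none of the three goes against this pattern. Compound 3 gives only a limit of the assay and not a number, and the step between cyclopropyl and ethyl cannot be read, because both of its ends are limits: the limit of < 5 mL.min-1.g-1 in this assay, at which 2 of the 3 values shown sit.

The compounds shown do not tell whether a methoxy group or an amine on this aromatic carbon would give a number nearer that of methylsulfanyl or that of ethyl. They also leave open whether a chain longer than ethyl would stay at the limit.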